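Methoxycarbonyl in Place of Methoxymethyl on the Shared Core

The source may hold more compounds than are shown below. What is called first, only, known or untested is meant among the compounds shown, and "the series" means these compounds.

Measured compounds:
- compound 1 `COCc1c(C)coc1-c1ccc2c(c1OC)CCCC2(C)C`: 47.8 uM
- compound 2 `Cc1coc(-c2ccc3c(c2O)CCC3)c1C(=O)O`: 44.6 uM
- compound 3 `COc1c(-c2occ(C)c2CO)ccc2c1CCCC2(C)C`: 28.3 uM

In a functional assay on MDA-MB-231 cells (Homo sapiens) for cytotoxicity, read by sulforhodamine B assay, with a stated time of 3 days (on this read-out higher numbers stand for an effect only at larger amounts of compound and lower numbers for an effect already at smaller amounts), compound 1 gives the highest of the three numbers, but its nearest neighbour compound 2 and its furthest neighbour compound 3 both lie within the scatter of it, so no ordering can be claimed. Compound 4 `COC(=O)c1c(C)coc1-c1ccc2c(c1OC)CCCC2(C)C` differs from compound 1 by methoxycarbonyl in place of methoxymethyl on an aromatic carbon. Among the compounds with values here, the only single-change step measured, a 1.7-fold lower number from compound 1 to compound 3 (0.23 log units; within the scatter), concerns a different alteration on this same side group and stayed within the scatter. Compound 2 differs in several places at once, and its value merely shows a similar number. Within the data shown here, no measured step therefore speaks for a sizable shift, and for compound 4 a change of a 1.1-fold lower number from compound 1 to compound 4 (0.03 log units; within the scatter) is expected, with compound 4 estimated at 45 uM (range 15 uM to 130 uM).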

Compound 4, concentration for half-maximal effect: 61 uM
Beside the measured number, compound 4's estimate is 1.4-fold (0.13 log units) below it; measured number inside the range.
By their numbers in this assay, from the lowest: compounds 3, 2, 1 and 4 (each within the scatter of the next, the first and the last beyond it).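

In this assay, methoxycarbonyl in place of methoxymethyl on this aromatic carbon gives a 1.3-fold higher number from compound 1 to compound 4 (0.11 log units; within the scatter), so this change alone cannot be told from repeat-measurement noise. Methoxycarbonyl in place of hydroxymethyl gives a 2.2-fold higher number from compound 3 to compound 4 (0.33 log units; beyond the scatter), the first step at this position to clear the scatter, though only modestly. Nothing available explains either step. Still open, on these data alone, is how an amide or an amine at this position would read out. A longer chain on the ester oxygen is equally untested by these compounds.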